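A few compounds are considered here, and "the series" means these few. Any claim that something is new, unique, unknown or untested is made for them only; others in the source may bear on it.

Compound 1 `CN(C)CCC(NC(=O)c1ccc(C(F)(F)F)cc1)c1ccc(Cl)cc1`: 115%
Compound 2 `Cc1cccc(C(=O)NC(CCN(C)C)c2ccc(Cl)cc2)c1C`: 159%
Compound 3 `Cc1c(Cl)cccc1C(=O)NC(CCN(C)C)c1ccc(Cl)cc1`: 142%

In an assay on NIH3T3 cells with Urotensin-2 receptor (Homo sapiens) as the target (on this read-out lower numbers stand for smaller maximal responses and higher numbers for larger maximal responses), compound 1 gives 115%, the lowest of the three numbers; both compound 2 and compound 3 lie above it beyond the scatter, compound 2 by the wider margin. Within the data shown here, the one step between neighbouring measured compounds, a number 17 percentage points lower from compound 2 to compound 3 (beyond the scatter), concerns a different position on the same aryl amide and a different exchange, chloro in place of methyl.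

Compound 4 `CN(C)CCC(NC(=O)c1ccc(Oc2ccccc2)cc1)c1ccc(Cl)cc1` differs from compound 1 by phenoxy in place of trifluoromethyl on an aromatic carbon. Among the measured compounds shown here, no measured pair tests a phenoxy group, so the step from compound 1 to compound 4 has no direct precedent; the only guide is that single-substituent changes on this aryl amide moved this assay by modest amounts. Compound 4 is therefore expected to stay near compound 1, with an estimated step of a number 10 percentage points higher from compound 1 to compound 4 (within the scatter), and its expected value is 125%, with a range from 90% to 165%.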

Compound 4, largest response reached (reported as efficacy), in percent of the reference or control that the assay uses: 89%
Compound 4: middle estimate off by 36 percentage points, on the high side; measured number outside the range, below it.
By their numbers in this assay, from the lowest: compound 4; then compound 1; then compound 3; then compound 2.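

In this assay, among these compounds, the exchange at this position gives a number 26 percentage points lower from compound 1 to compound 4 (beyond the scatter), the first measured step at the place on an aromatic carbon para to a large group, and it shows that a change here can lower the maximal response beyond the scatter. Phenoxy brings one six-membered aromatic ring and one hydrogen-bond acceptor where trifluoromethyl has neither, but this single step cannot separate the ring from the oxygen. Nothing available accounts for the lower number.

The compounds shown leave open whether a methoxy group, which keeps the oxygen without the ring, or a phenyl group, which keeps the ring without the oxygen, would stand nearer compound 1 or compound 4. They also leave open whether a benzyloxy group, with its longer link to the ring, would continue this step.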